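Phenyl for Benzyl on the Sulfonamide Nitrogen

A few compounds are considered here, and "the series" means these few. Any claim that something is new, unique, unknown or untested is made for them only; others in the source may bear on it.

Compound 2, with structure `O=C(Nc1ccc(S(=O)(=O)NCc2ccccc2)cc1)c1ccc(Cl)cc1Cl`, has no result in a functional assay on HEK293 cells for agonist activity at probable G-protein coupled receptor 27 (Homo sapiens), read by a luciferase reporter and beta-arrestin recruitment, with a stated time of 10 min (a higher number here means a larger maximal response, a lower number a smaller maximal response), recorded only as "not determined" (no result reported): it stands nowhere on the numbers shown. Two other members of the series do have values. Compound 1, `O=C(Nc1ccc(S(=O)(=O)Nc2ccccc2)cc1)c1cc(F)c(Cl)cc1F`, gives 37% in this assay, and compound 3, `O=C(Nc1ccc(S(=O)(=O)Nc2cccc(Cl)c2)cc1)c1ccc(Cl)cc1Cl`, gives 40% in this assay; these two values lie within the scatter of each other, so neither can be called larger. Both carry a phenyl on the sulfonamide nitrogen, where compound 2 carries a benzyl.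

Compound 4, `O=C(Nc1ccc(S(=O)(=O)Nc2ccccc2)cc1)c1ccc(Cl)cc1Cl`, is reached from compound 2 by the change (phenyl in place of benzyl on a sulfonamide nitrogen). Because compound 2 has no number, the size and direction of this step cannot be read from the data. The expectation for compound 4 therefore rests on compound 1 and compound 3 alone, both of which already carry the phenyl that enters here. Compound 4 is expected to give about 38% in this assay, estimated between 20% and 58%.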

Compound 4, largest response reached (Emax), in percent of the reference or control that the assay uses: 100%
Compound 4: the middle estimate sits 62 percentage points below what was measured; the whole stated range lies below it.
By their numbers in this assay, from the lowest: compounds 1 and 3 (each within the scatter of the next); then compound 4.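

Carrying a phenyl on the sulfonamide nitrogen does not settle the response in this assay, since compounds 1, 3 and 4 all have one and still differ widely. Hydrogen in place of chloro on an aromatic carbon of that phenyl gives a number 60 percentage points higher from compound 3 to compound 4 (beyond the scatter), and 2,4-dichlorophenyl in place of 4-chloro-2,5-difluorophenyl on a carbonyl carbon gives a number 63 percentage points higher from compound 1 to compound 4 (beyond the scatter), so small edits at either end of the shared core each move the maximal response well beyond the scatter. Nothing available explains why either edit has this effect.

With no number for compound 2, the effect of phenyl in place of benzyl itself cannot be read. As far as these compounds go, how a methoxy or a fluoro on that phenyl, or a longer chain such as phenethyl on the sulfonamide nitrogen, would behave also remains open.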